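Chloro for amino on the purine core: two benzyl analogs

The compounds below may be only part of what the source reports. "The series", "measured", "known", "first", "only" and "open" are said of these compounds alone.

Going by the values given here, compound 1 `Nc1nc(Cl)c2ncn(Cc3ccccc3CCl)c2n1` and compound 2 `ClCc1ccc(Cn2cnc3c(Cl)nc(Cl)nc32)cc1` are the two measured members of this small set. In a functional assay on OVCAR-5 cells (Homo sapiens) for cytotoxicity, read by sulforhodamine B assay, with a stated time of 48 h (a lower number here means a stronger inhibitor of growth, a higher number a weaker inhibitor of growth), compound 1 gives 20000 nM, the highest of the two numbers recorded. In this assay compound 2 gives 18200 nM, which sits within the usual scatter of the value for compound 1, so no order can be read between these two.

The next compound, compound 3 `ClCc1ccccc1Cn1cnc2c(Cl)nc(Cl)nc21`, is reached from compound 1 by a single change: chloro in place of amino on an aromatic carbon. Among the compounds with values here, no measured pair carries exactly this change on this core, so the size of the step must be judged from what the two numbers show. Compound 2 already carries the dichloro pattern that compound 3 will have, and its value in this assay lies within the scatter of compound 1, which gives no hint of a move in either direction.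

The step from compound 1 to compound 3 in this assay is therefore expected to be small, a 1.3-fold lower number from compound 1 to compound 3 (0.10 log units; within the scatter), and not beyond the scatter. Compound 3 is estimated at 16000 nM in this assay, with a range from 5000 nM to 50000 nM.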

Compound 3, concentration for 50% growth inhibition: 1580 nM
Compound 3: middle estimate off by 10-fold (1.01 log units), on the high side; measured number below the stated range.
By their numbers in this assay, from the lowest: compound 3; then compounds 2 and 1 (each within the scatter of the next).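

In this assay, the exchange of amino for chloro on the aromatic carbon between two ring nitrogen atoms gives a 13-fold lower number from compound 1 to compound 3 (1.10 log units; beyond the scatter), so this position is not indifferent to the group it carries. Going by these compounds alone, this is the first step that lies beyond the scatter, and it pairs the loss of the amino group with a clear gain in growth inhibition on the core of compound 1. Chloro at this carbon does not alone ensure a low number, however: compound 2 also carries it and gives 18200 nM, while differing from compound 3 in where the chloromethyl group sits on the benzyl ring. No measurement shown here explains the size of the step.

Whether the step is particular to chloro remains open, as the compounds shown do not include a fluoro, bromo, methyl or methoxy group on this carbon. Within the data shown here, it also remains open whether the same exchange gives a step of similar size in the arrangement of compound 2, since no amino and chloro pair tests it there.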